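Lengthening the chain from compound 3 to compound 4

The source may report more compounds than this note shows. Statements on the series, on what has been measured and on what is new or still open speak of the compounds shown alone.

Measured so far in a functional assay, with a stated time of 30 min; on this read-out lower numbers stand for stronger inhibition and higher numbers for weaker inhibition:
compound 1 `CCCCCCCCOc1cc(OC)c(Br)cc1C(C)=O` gives 39000000 nM
compound 2 `CCOc1cc(OC)ccc1C(C)=O` gives 39600000 nM
compound 3 `CCCCCCCCOc1cc(OC)ccc1C(C)=O` gives 40000000 nM

Compound 3 lies within the scatter of both other compounds, so the three values form a single level. Compound 4 `CCCCCCCCCCCCCCCCOc1cc(OC)ccc1C(C)=O` has not been measured. Its difference from compound 3 is octyl in place of hydrogen on a saturated chain carbon, eight bonds along the chain from an oxygen on an aromatic ring.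

Among the compounds with values here, the closest precedent is the hexyl extension of the same chain, a 1.0-fold higher number from compound 2 to compound 3 (0.00 log units; within the scatter). Hydrogen in place of bromo, a 1.0-fold higher number from compound 1 to compound 3 (0.01 log units; within the scatter), bears on the question only indirectly. Within the data shown here, neither step leaves the scatter, and no measured compound carries a chain longer than octyl, so the expectation rests on a short reach of data.

No change beyond the scatter is expected in this assay. The expected step is a 1.0-fold lower number from compound 3 to compound 4 (0.01 log units; within the scatter). For compound 4 the estimated value is 39000000 nM, with an expected range of 15000000 nM to 80000000 nM.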

Compound 4, half-maximal inhibitory concentration: 39400000 nM
The estimate for compound 4 lay 1.0-fold (0.00 log units) below the measured number; measured number inside the range.
By their numbers in this assay, from the lowest: compounds 1, 4, 2 and 3 (each within the scatter of the next).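

In this assay, octyl in place of hydrogen on a saturated chain carbon, eight bonds along the chain from an oxygen on an aromatic ring, leaves the read-out at the same level (a 1.0-fold lower number from compound 3 to compound 4 (0.01 log units; within the scatter)). The earlier hexyl extension also stayed within the scatter (a 1.0-fold higher number from compound 2 to compound 3 (0.00 log units; within the scatter)), and the new step shows the same flat result with the chain of compound 4, the longest in the set, so chain length at this position has not separated any compounds here. No supporting measurement bears on this flat result.

As far as these compounds go, it remains open whether an amine or a carboxylic acid carried on this chain would move the read-out away from this level in this assay. From the compounds shown here alone, it is equally open whether a nitrile in place of the bromo of compound 1 would separate from it.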